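The compounds below may be only part of what the source reports. "The series", "measured", "known", "first", "only" and "open" are said of these compounds alone.

Going by the values given here, compound 1 `Nc1nc(NCc2ccc(Cl)cc2)nc(-c2ccccc2CO)n1` stands highest of the two compounds measured so far: in a functional assay on cells for positive allosteric modulation of G-protein coupled receptor 68 (Homo sapiens), read by a luciferase reporter and cAMP accumulation, with a stated time of 30 min, at pH 6.8 and pH 8.3, in the presence of a further agent that is not named here (a higher number here means a more potent compound, by a factor of ten per unit of this negative logarithm, a lower number a less potent compound), compound 1 gives 5.22. Compound 2 `COc1cccc(CNc2nc(N)nc(-c3ccccc3CO)n2)c1` carries 3-methoxyphenyl in place of 4-chlorophenyl on the saturated chain carbon bound to a nitrogen on an aromatic ring, and in this assay compound 2 gives 4.11; the step of a number 1.11 log units lower from compound 1 to compound 2 (beyond the scatter) is large and well beyond the scatter. Compound 3 `CC(C)Oc1ccc(CNc2nc(N)nc(-c3ccccc3CO)n2)cc1` is not yet measured. It differs from compound 1 by isopropoxy in place of chloro on an aromatic carbon. Among the compounds with values here, only the step from compound 1 to compound 2 bears on this change, and it is not a clean match: it moved the substituent and replaced it at once. That one step shows that leaving the chloro pattern of compound 1 cost potency. For compound 3 a drop is therefore expected, smaller than that step, with a number 0.52 log units lower from compound 1 to compound 3 (beyond the scatter). Compound 3 is estimated at 4.7, with a range from 4 to 5.4.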

Compound 3, negative logarithm of the antagonist equilibrium constant: 4.99
Beside the measured number, compound 3's estimate is 0.29 log units below it; low and high end bracket the measured number.
By their numbers in this assay, from the lowest: compound 2; then compounds 3 and 1 (each within the scatter of the next).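

In this assay, the step of a number 0.23 log units lower from compound 1 to compound 3 (within the scatter) shows that at this aromatic carbon, para to a large group, isopropoxy can stand in place of chloro with no difference that can be told from the scatter. Leaving chloro therefore need not cost potency by itself, so the earlier step of a number 1.11 log units lower from compound 1 to compound 2 (beyond the scatter) cannot be read as loss of chloro alone, since that change also moved the substituent on the ring. No measurement at hand bears on why both groups are accepted here.

On these data alone, a methoxy on this same carbon would separate the place of the substituent from its identity, and that comparison remains open. Also open, as far as these compounds go, is whether the tolerance extends to an amine, a carboxylic acid or a longer alkoxy chain at this position.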